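Methoxy in Place of Fluoro: What Compound 4 May Show

A few compounds are considered here, and "the series" means these few. Any claim that something is new, unique, unknown or untested is made for them only; others in the source may bear on it.

Compound 1 `COc1ccc2c(/C=C(\C#N)C(=O)c3c[nH]c4cc(F)ccc34)c[nH]c2c1` and compound 2 `COc1ccc2c(/C=C(\C#N)C(=O)c3c[nH]c4cc(OC)ccc34)c[nH]c2c1` differ by methoxy in place of fluoro on an aromatic carbon. In a functional assay on MIA PaCa-2 cells (Homo sapiens) for cytotoxicity, read by WST assay, with a stated time of 48 h (a lower number here means a stronger inhibitor, a higher number a weaker inhibitor), compound 1 gives > 50000 nM, which is a limit of the assay and not a number. In this assay compound 2 gives > 50000 nM, likewise a limit. The step that the two limits leave unreadable from compound 1 to compound 2 therefore cannot be read, because of the limit of > 50000 nM in this assay, at which 2 of the 3 values shown sit. Among the measured compounds shown here, compound 3 `N#C/C(=C\c1cn(Cc2ccc(Cl)cc2)c2ccccc12)C(=O)c1c[nH]c2cc(F)ccc12` gives 16600 nM in this assay, the only number among the three. The difference between the cores of compound 1 and compound 3 is not broken down here. Compound 4 `COc1ccc2c(C(=O)/C(C#N)=C/c3cn(Cc4ccc(Cl)cc4)c4ccccc34)c[nH]c2c1` is compound 3 with methoxy in place of fluoro on an aromatic carbon, the same change at the same place as the measured pair, whose two limits give it no size. For the measured compounds named here, the one anchor is compound 3 at 16600 nM. Compound 4 is therefore expected close by, at 20000 nM, a step of a 1.2-fold higher number from compound 3 to compound 4 (0.08 log units; within the scatter) in this assay, estimated between 6000 nM and 60000 nM.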

Compound 4, half-maximal inhibitory concentration: 40400 nM
Compound 4: middle estimate off by 2.0-fold (0.31 log units), on the low side, and the stated range covers the measured number.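

In this assay the change gives a 2.4-fold higher number from compound 3 to compound 4 (0.39 log units; beyond the scatter) and this step lies beyond the scatter, so on the core of compound 3 methoxy in place of fluoro gives a weaker inhibitor. This single step describes one core and does not show that the change carries over from one core to another. The same change on the core of compound 1 cannot be read, because compound 1 and compound 2 both give only a limit of the assay: the limit of > 50000 nM in this assay, at which 2 of the 4 values shown sit.

The compounds shown leave open how an amine or a carboxylic acid in place of fluoro would read on the core of compound 3. They also leave open whether ethoxy, a longer chain than methoxy, would follow the same direction.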